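The compounds below may be only part of what the source reports. "The series", "measured", "known", "first", "only" and "open" are said of these compounds alone.

In an ADME assay on HEK293 cells (Homo sapiens) for inhibition, read by MTT assay, with a stated time of 3 days (a lower number here means a stronger inhibitor, a higher number a weaker inhibitor), compound 1 `COc1ccc(COc2cc(/C=C\c3cc(OC)c(OC)c(OC)c3)ccc2OC)cc1` gives 64000 nM, the highest of the three numbers measured. Compound 2 `COCOc1cccc(/C=C/CCCOc2cc(/C=C\c3cc(OC)c(OC)c(OC)c3)ccc2OC)c1` gives 30000 nM and compound 3 `COCOc1ccc(/C=C/CCCOc2cc(/C=C\c3cc(OC)c(OC)c(OC)c3)ccc2OC)cc1` gives 25000 nM; putting 4-(methoxymethoxy)phenyl in place of 3-(methoxymethoxy)phenyl on a double-bonded chain carbon bound to a double-bonded chain carbon amounts to a 1.2-fold lower number from compound 2 to compound 3 (0.08 log units; within the scatter). Compound 4 `COc1ccc(/C=C\c2cc(OC)c(OC)c(OC)c2)cc1OCCC/C=C/c1ccc(Cl)cc1` differs from compound 1 in one place: 4-(4-chlorophenyl)but-3-en-1-yl in place of 4-methoxyphenyl on a saturated chain carbon bound to an oxygen on an aromatic ring. For the measured compounds named here, no measured step repeats this exact change. The nearest guide is that compounds 2 and 3, whose chains likewise end in a substituted phenyl, both show lower numbers than compound 1. Compound 4 is therefore expected to give about 25000 nM, within 8000 nM to 80000 nM. That estimate means a step of a 2.6-fold lower number from compound 1 to compound 4 (0.41 log units; beyond the scatter), a lower number beyond the scatter.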

Compound 4, half-maximal inhibitory concentration: 111000 nM
For compound 4 the middle estimate is 4.4-fold (0.65 log units) below the measured one; the whole stated range lies below it.
By their numbers in this assay, from the lowest: compounds 3 and 2 (each within the scatter of the next); then compounds 1 and 4 (each within the scatter of the next).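

In this assay the exchange of 4-methoxyphenyl for 4-(4-chlorophenyl)but-3-en-1-yl gives a 1.7-fold higher number from compound 1 to compound 4 (0.24 log units; within the scatter) on a saturated chain carbon bound to an oxygen on an aromatic ring, so this chain alone does not set compound 4 apart from compound 1. The group on the chain's phenyl ring does: chloro in place of methoxymethoxy on an aromatic carbon gives a 4.4-fold higher number from compound 3 to compound 4 (0.65 log units; beyond the scatter) and 4-chlorophenyl in place of 3-(methoxymethoxy)phenyl gives a 3.7-fold higher number from compound 2 to compound 4 (0.57 log units; beyond the scatter) with the chain otherwise unchanged. Nothing available explains these steps. From the compounds shown here alone, whether an amine or a carboxylic acid in place of chloro would give a number nearer that of compound 3 stays open.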